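The source may report more compounds than this note shows. Statements on the series, on what has been measured and on what is new or still open speak of the compounds shown alone.

Working notes on the series in an assay on isolated protein for binding affinity to sphingosine 1-phosphate receptor 2 (Homo sapiens), read by surface plasmon resonance; a higher number here means weaker binding, a lower number tighter binding.

Of the compounds shown here, three carry a number so far. Compound 1 `Cn1ncc2c(-c3ccc(F)cc3)cc(NNC(=O)Nc3cc(Cl)cc(Cl)c3)nc21` gives 4980 nM in this assay. Compound 2 `COc1ccc(-c2cc(NNC(=O)Nc3cc(Cl)nc(Cl)c3)nc3c2c(C)nn3C)cc1` gives 1020 nM. Compound 3 `COc1ccc(-c2cc(NNC(=O)Nc3cc(Cl)nc(Cl)c3)nc3c2cnn3C)cc1` gives 520 nM. For the measured compounds named here, on these numbers compound 2 stands second highest of the three: its nearest neighbour is compound 3, and the one measured step, a 2.0-fold lower number from compound 2 to compound 3 (0.29 log units; within the scatter), lies within the scatter; compound 1 sits furthest from compound 2, its number beyond the scatter higher, but compound 1 differs from compound 2 in more than one place, so no single step can be drawn between them.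

Compound 4 `Cc1nn(C)c2nc(NNC(=O)Nc3cc(Cl)nc(Cl)c3)cc(-c3ccccc3)c12` is not yet measured. It differs from compound 2 as follows: hydrogen in place of methoxy on an aromatic carbon. Going by the values given here, no measured pair changes the methoxy on the six-membered aromatic ring of carbon only, so the only step on record, from compound 2 to compound 3, touches a different position and does not bear on this change directly; it shows only that a small removal elsewhere on the shared core stayed within the scatter.

With nothing directly comparable, a step of modest size is expected, leaning toward a higher number: a 1.6-fold higher number from compound 2 to compound 4 (0.20 log units; within the scatter). Compound 4 is therefore estimated at 1600 nM, with a range from 500 nM to 5000 nM.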

Compound 4, dissociation constant: 5320 nM
Estimate against measurement, compound 4: 3.3-fold (0.52 log units) below; measured number above the stated range.
By their numbers in this assay, from the lowest: compounds 3 and 2 (each within the scatter of the next); then compounds 1 and 4 (each within the scatter of the next).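

In this assay, for the compounds shown here, the change from 4-methoxyphenyl to phenyl gives the first step that lies beyond the scatter: a 5.2-fold higher number from compound 2 to compound 4 (0.72 log units; beyond the scatter). Going by these compounds alone, the only earlier step, a 2.0-fold lower number from compound 2 to compound 3 (0.29 log units; within the scatter), lies within the scatter and sits at a different position on the shared core, so it gave no sign of how the number would respond at this one. The methoxy, on an aromatic carbon para to a large group, now stands as a place where the number does respond, with weaker binding when hydrogen takes its place; no measurement at hand accounts for this, and the step stands as an observation only.

The compounds shown leave open whether this difference belongs to methoxy itself or would also appear with another group in the same place, such as a hydroxyl, an ethoxy, a chlorine or an amine. They also leave open whether the step would keep its size on the core of compound 3, which lacks the methyl on the aromatic carbon that compound 2 and compound 4 share.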